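The source may hold more compounds than are shown below. What is called first, only, known or untested is meant among the compounds shown, and "the series" means these compounds.

Compound 1, `CCC1(CCCCN2CC=C(c3ccc(Cl)cc3)CC2)C(=O)Nc2ccccc21`: 1.02 nM
Compound 2, `CCC1(CCCCN2CCN(c3ccc(OC)cc3)CC2)C(=O)Nc2ccccc21`: 25.4 nM
Compound 3, `CCC1(CCCCN2CC=C(c3ccc(F)cc3)CC2)C(=O)Nc2ccccc21`: 1.19 nM

All three were tested in an assay on CHO cells for displacement of a labelled ligand from 5-hydroxytryptamine receptor 7 (Homo sapiens); a higher number here means a weaker inhibitor, a lower number a stronger inhibitor. Compound 2 stands at the highest number of the three, and both compound 1 and compound 3 lie far below it, beyond the scatter, so compound 2 is the weakest inhibitor in this set. Compound 4, `CCC1(CCCCN2CCN(c3ccc(C)c(Cl)c3)CC2)C(=O)Nc2ccccc21`, is not yet measured; it differs from compound 2 by 3-chloro-4-methylphenyl in place of 4-methoxyphenyl on an amine nitrogen in a ring.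

Among the compounds with values here, only one measured step changes an aromatic substituent: a 1.2-fold higher number from compound 1 to compound 3 (0.07 log units; within the scatter), which left the number essentially unchanged. That step, however, sits on the core of compound 1, and it exchanges one halogen for another rather than a methoxy group for a chlorine and a methyl group. Within the data shown here, no measured pair exchanges these groups on the ring nitrogen, so the expectation is loosely held. Compound 4 is expected to give about 15 nM, within a range of 3 nM to 60 nM. The step of a 1.7-fold lower number from compound 2 to compound 4 (0.23 log units; within the scatter) is thus expected to be modest and may well fall within the scatter.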

Compound 4, inhibition constant: 0.66 nM
The estimate for compound 4 lay 23-fold (1.36 log units) above the measured number; measured number outside the range, below it.
By their numbers in this assay, from the lowest: compounds 4, 1 and 3 (each within the scatter of the next); then compound 2.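

In this assay, the group on the amine nitrogen in a ring proves to be a sensitive place: 3-chloro-4-methylphenyl in place of 4-methoxyphenyl gives a 38-fold lower number from compound 2 to compound 4 (1.59 log units; beyond the scatter), a large step. Both groups have 8 heavy atoms and one six-membered aromatic ring of carbon only, so a change of this size appears without any change in those counts. The entering group has 0 hydrogen-bond acceptors and the leaving group 1, but nothing measured here explains the size of the step.

This single step exchanges the methoxy group for both a chloro and a methyl group, so it leaves open which of them carries the gain, or whether the loss of the methoxy group does. A phenyl group bearing only the chloro or only the methyl would address this, while a pyridine ring at this place remains an open question.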